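Furan Isomers on a Nucleoside Core: Expected Limit for Compound 4

The source may hold more compounds than are shown below. What is called first, only, known or untested is meant among the compounds shown, and "the series" means these compounds.

Compound 1 `O=c1[nH]cnc2c1c(-c1ccoc1)cn2[C@@H]1O[C@H](CO)[C@@H](O)[C@H]1O` and compound 2 `O=c1[nH]cnc2c1c(-c1ccco1)cn2[C@@H]1O[C@H](CO)[C@@H](O)[C@H]1O` share one core and differ only in one place: furan-2-yl in place of furan-3-yl on an aromatic carbon. In an ADME assay on BJ cells (Homo sapiens), read by MTT assay, with a stated time of 72 h (on this read-out lower numbers stand for stronger inhibition and higher numbers for weaker inhibition), compound 1 gives only a limit, > 100000 nM. Compound 2 likewise gives only a limit in this assay, > 100000 nM. The step that the two limits leave unreadable from compound 1 to compound 2 therefore cannot be sized, since both ends rest on (the limit of > 100000 nM in this assay, at which 3 of the 3 values shown sit). Compound 3 `COc1nc(N)nc2c1c(-c1ccoc1)cn2[C@@H]1O[C@H](CO)[C@@H](O)[C@H]1O` carries a different core; how its core differs from that of compound 1 is not broken down here. In this assay compound 3 also gives only a limit, > 100000 nM. Compound 4 `COc1nc(N)nc2c1c(-c1ccco1)cn2[C@@H]1O[C@H](CO)[C@@H](O)[C@H]1O` is not yet measured and differs from compound 3 by furan-2-yl in place of furan-3-yl on an aromatic carbon, the same change as from compound 1 to compound 2, at the same place. Because all three measured values sit at the limit of > 100000 nM in this assay, at which 3 of the 3 values shown sit, the earlier step offers no readable size to carry over, and the step that the limit leaves unreadable from compound 3 to compound 4 is expected to be small. Compound 4 is accordingly expected to give 200000 nM in this assay, most likely reported again as a limit, within a range from 100000 nM to 500000 nM.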

Compound 4, half-maximal inhibitory concentration: > 100000 nM
Compound 4: only a limit was reported; the forecaster's own chance of this, stated with the estimate: 90%; the middle value does not contradict the limit.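

Compound 3 and compound 4 each give only a limit in this assay, so no size can be read for the step between them: the limit of > 100000 nM in this assay, at which 4 of the 4 values shown sit.

The compounds shown leave open whether furan-2-yl and furan-3-yl differ at all in this assay, on either core, since none of the four has a value beyond a limit.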